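A few compounds are considered here, and "the series" means these few. Any claim that something is new, unique, unknown or untested is made for them only; others in the source may bear on it.

Among the compounds with values here, compound 1 `Cc1cc(NC(=O)Cn2nnc(-c3ccccc3)n2)n(C2CCCCC2)n1` reaches in an assay on HEK293 cells for activation of Kir3.1/Kir3.2 (Homo sapiens), read by thallium flux (a higher number here means a larger maximal response, a lower number a smaller maximal response), a value of 92%, the only plain number among the measured compounds. Compound 2 `Cc1cc(NC(=O)Cn2nnc(-c3ccccc3)n2)n(C2CCS(=O)(=O)CC2)n1` gives in this assay only a limit, > 25%. The step that the limit leaves unreadable from compound 1 to compound 2 therefore has no readable size because of the limit of > 25% in this assay, at which 1 of the 2 values shown sits. Compound 3 `Cc1cc(NC(=O)Cn2nnc(-c3ccccc3)n2)n(CC2CCCCC2)n1` differs from compound 1 by cyclohexylmethyl in place of cyclohexyl on an aromatic nitrogen. Within the data shown here, no measured step speaks to this change, so the expectation rests on compound 1 alone, with room for a modest fall. Compound 3 is expected to reach 75% in this assay, within 40% to 105%, which corresponds to an estimated step of a number 17 percentage points lower from compound 1 to compound 3 (beyond the scatter).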

Compound 3, largest response reached (Emax), in percent of the reference or control that the assay uses: 77%
Compound 3: middle estimate off by 2 percentage points, on the low side; the measured number falls inside the stated range.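

In this assay, within the data shown here, cyclohexylmethyl in place of cyclohexyl on the aromatic nitrogen gives the first readable step at this position, a number 15 percentage points lower from compound 1 to compound 3 (beyond the scatter). The position therefore accepts this slightly larger group with only a modest loss of maximal response, while the six-membered ring of carbon only stays the same. The steps involving compound 2 cannot be read, because the value of compound 2 is a limit: the limit of > 25% in this assay, at which 1 of the 3 values shown sits.

The compounds shown leave open whether a longer chain, such as cyclohexylethyl, would lower the response further. Going by these compounds, how a piperidin-4-yl ring, which carries an amine, would read at this position also stays open.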